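From Sulfanyl to Sulfonyl on a Saturated Chain

The compounds below may be only part of what the source reports. "The series", "measured", "known", "first", "only" and "open" are said of these compounds alone.

Values in a functional assay for inhibition, with Homo sapiens as the target; on this read-out lower numbers stand for stronger inhibition and higher numbers for weaker inhibition:
- compound 1 `O=C(O)CCCCCCCn1nc(-c2ccccc2)c(-c2ccccc2)c1-c1ccccc1`: 3400 nM
- compound 2 `CC(C)(C)OC(=O)COCCCCCCn1nc(-c2ccccc2)c(-c2ccccc2)c1-c1ccccc1`: > 62000 nM (a limit, not a number)
- compound 3 `O=C(O)CSCCCCCCn1nc(-c2ccccc2)c(-c2ccccc2)c1-c1ccccc1`: 870 nM

Compound 3 has the lower of the two true numbers, as a 3.9-fold lower number from compound 1 to compound 3 (0.59 log units; beyond the scatter) shows. The next candidate, compound 4 `O=C(O)CS(=O)(=O)CCCCCCn1nc(-c2ccccc2)c(-c2ccccc2)c1-c1ccccc1`, has (carboxymethyl)sulfonyl in place of (carboxymethyl)sulfanyl, on a saturated chain carbon, six bonds along the chain from an aromatic nitrogen: (carboxymethyl)sulfonyl in place of (carboxymethyl)sulfanyl on a saturated chain carbon, six bonds along the chain from an aromatic nitrogen.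

The closest guide is the modest 3.9-fold lower number from compound 1 to compound 3 (0.59 log units; beyond the scatter), which also alters this chain while keeping the acid. The large at least 71-fold lower number from compound 2 to compound 3 (1.85 log units; beyond the scatter) also removes the tert-butoxycarbonyl group, so it says less here. A modest 2.1-fold higher number from compound 3 to compound 4 (0.32 log units; beyond the scatter) is expected, though its direction is uncertain. Compound 4 is estimated at 1800 nM, within 450 nM to 7000 nM.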

Compound 4, half-maximal inhibitory concentration: 22000 nM
For compound 4 the middle estimate is 12-fold (1.09 log units) below the measured one; the measured number lies above the stated range.
By their numbers in this assay, from the lowest: compound 3; then compound 1; then compound 4. At a limit, above all of these: compound 2.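

Changing sulfanyl to sulfonyl at this place has a large effect on the number, far larger than the change from the all-carbon chain to the sulfanyl chain: a 25-fold higher number from compound 3 to compound 4 (1.40 log units; beyond the scatter). The advantage of compound 3 is lost with the sulfonyl, which also falls behind the all-carbon acid, with a 6.5-fold higher number from compound 1 to compound 4 (0.81 log units; beyond the scatter). Compound 2 sits at a limit, so an at least 2.8-fold lower number from compound 2 to compound 4 (0.44 log units; beyond the scatter) gives only a bound: the limit of > 62000 nM in this assay, at which 1 of the 4 values shown sits.

Open, going by these compounds, is where a (carboxymethyl)sulfinyl chain would fall relative to compound 3 and compound 4. Also open, on these data alone, is how a free carboxylic acid on an ether chain, with oxygen in place of the sulfur, would compare.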